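This account rests on a few compounds, and the source may have more. Where it says the series, first, only, none or still open, it means among the compounds named here.

Measured in an ADME assay on L6 cells (Rattus norvegicus) for cytotoxicity; a lower number here means a stronger inhibitor, a higher number a weaker inhibitor:

- compound 1 `N#Cc1ccccc1N1CCN(C(=O)Cn2cnc([N+](=O)[O-])n2)CC1`: 213000 nM
- compound 2 `Cc1ccc(N2CCN(C(=O)Cn3cnc([N+](=O)[O-])n3)CC2)cc1`: 148000 nM
- compound 3 `O=C(Cn1cnc([N+](=O)[O-])n1)N1CCN(c2ccc(Cl)cc2)CC1`: > 285000 nM (a limit, not a number)

Compound 3 has no exact reading, only the limit > 285000 nM. Its true position in this assay is therefore open on the high side, and it stands at the limit of > 285000 nM in this assay, at which 1 of the 3 values shown sits.

Compound 4 `O=C(Cn1cnc([N+](=O)[O-])n1)N1CCN(c2ccc(Cl)c(Cl)c2)CC1` has not yet been measured. It differs from compound 3 by chloro in place of hydrogen on an aromatic carbon, which turns 4-chlorophenyl into 3,4-dichlorophenyl.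

Within the data shown here, no measured step makes this exact change, so the nearest guides are the other changes on the same aromatic ring. Chloro in place of methyl gives an at least 1.9-fold higher number from compound 2 to compound 3 (0.28 log units; that floor lies within the scatter). Changing the ring substituents also gives a 1.4-fold lower number from compound 1 to compound 2 (0.16 log units; within the scatter) and an at least 1.3-fold higher number from compound 1 to compound 3 (0.12 log units; that floor lies within the scatter). All three are small, so altering this ring has not yet moved the number beyond the scatter. Only a modest step is therefore expected, with no change beyond the scatter, and any lean is towards a lower number, since compound 3 is recorded only at a limit.

The expected change is an at least 1.6-fold lower number from compound 3 to compound 4 (0.22 log units; that floor lies within the scatter). Compound 4 is estimated at 170000 nM, with an expected range from 60000 nM to 290000 nM.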

Compound 4, half-maximal inhibitory concentration: 108000 nM
Compound 4: middle estimate off by 1.6-fold (0.20 log units), on the high side, and the stated range covers the measured number.
By their numbers in this assay, from the lowest: compounds 4, 2 and 1 (each within the scatter of the next). At a limit, above all of these: compound 3.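

In this assay, among these compounds, a chloro placed ortho to the existing chloro group and meta to a large group gives an at least 2.6-fold lower number from compound 3 to compound 4 (0.42 log units; beyond the scatter), the first change on this aromatic ring that is printed as beyond the scatter; the earlier changes on the ring all stayed within it. The effect does not set compound 4 apart from the other compounds with exact values, as the 3,4-dichlorophenyl group gives a 1.4-fold lower number from compound 2 to compound 4 (0.14 log units; within the scatter) and a 2.0-fold lower number from compound 1 to compound 4 (0.29 log units; within the scatter), both within the scatter. The step from the 4-chlorophenyl group has only a floor for its size, and compound 3 is recorded as a limit, not a number: the limit of > 285000 nM in this assay, at which 1 of the 4 values shown sits.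

From the compounds shown here alone, it remains open whether a fluoro, a methoxy or an amine on this same aromatic carbon would give a similar step, and whether a chloro here would do so without the other chloro on the ring. Going by these compounds, all four compounds also share the rest of their structure, so the effect of a longer chain in the shared core, or of a carboxylic acid on the ring, remains unknown.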